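The source may report more compounds than this note shows. Statements on the series, on what has been measured and on what is new or still open speak of the compounds shown alone.

In an ADME assay on HEK293 cells (Homo sapiens) for cytotoxicity, read by MTT assay, with a stated time of 72 h (a lower number here means a stronger inhibitor, a higher number a weaker inhibitor), compound 1 `O=C(CN1CCN(C(=O)c2ccc(Br)cc2)CC1)N1CCN(CCCc2c[nH]c3ccccc23)CC1` gives 71900 nM, compound 2 `O=C(CN1CCN(C(=O)c2ccccc2)CC1)N1CCN(CCCc2c[nH]c3ccc(F)cc23)CC1` gives 148000 nM, and compound 3 `COc1ccc(C(=O)N2CCN(CC(=O)N3CCN(CCCc4c[nH]c5ccc(F)cc45)CC3)CC2)cc1` gives 141000 nM. Compound 3 therefore lies within the scatter of both other compounds. The next compound, compound 4 `O=C(CN1CCN(C(=O)c2ccc(Br)cc2)CC1)N1CCN(CCCc2c[nH]c3ccc(F)cc23)CC1`, has bromo in place of methoxy on an aromatic carbon, para to a large group: bromo in place of methoxy on an aromatic carbon. Within the data shown here, only one measured step changes this same group: a 1.0-fold lower number from compound 2 to compound 3 (0.02 log units; within the scatter), with methoxy in place of hydrogen, and it stays within the scatter. That step involves no bromo, so it offers only indirect guidance. The nearest bromo evidence is compound 1, which carries the same 4-bromophenyl group on a slightly different core and gives 71900 nM. Together, these results suggest no change beyond the scatter in this assay, with a slight lean towards a lower number. The expected step is a 1.3-fold lower number from compound 3 to compound 4 (0.11 log units; within the scatter), which would stay within the scatter. For compound 4, the estimated value is 110000 nM, with an expected range from 60000 nM to 190000 nM.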

Compound 4, half-maximal inhibitory concentration: 60500 nM
Beside the measured number, compound 4's estimate is 1.8-fold (0.26 log units) above it, within the range that was stated.
By their numbers in this assay, from the lowest: compounds 4, 1, 3 and 2 (each within the scatter of the next, the first and the last beyond it).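

In this assay, among these compounds, the group para to a large group on this aromatic ring now matters beyond the scatter for the first time. Bromo in place of methoxy gives a clear step (a 2.3-fold lower number from compound 3 to compound 4 (0.37 log units; beyond the scatter)), and bromo in place of hydrogen gives one of similar size (a 2.4-fold lower number from compound 2 to compound 4 (0.39 log units; beyond the scatter)), whereas methoxy in place of hydrogen had stayed within the scatter (a 1.0-fold lower number from compound 2 to compound 3 (0.02 log units; within the scatter)). Fluoro in place of hydrogen on the core, with bromo already present, also stays within the scatter (a 1.2-fold lower number from compound 1 to compound 4 (0.07 log units; within the scatter)), so among these compounds only the bromo steps go beyond it. No measured property of these compounds bears on this result.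

The compounds shown leave open whether chloro, a nitrile or an amine at this place would give a similar step. They also leave open whether any such step is specific to bromo.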